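This account rests on a few compounds, and the source may have more. Where it says the series, first, only, none or still open, it means among the compounds named here.

Compound 1 `COc1cccc2c(=O)cc(/C=C/[S+](C)[O-])oc12`: 2200 nM
Compound 2 `C[S+]([O-])/C=C/c1cc(=O)c2cc(C#N)ccc2o1`: > 10000 nM
Compound 3 `Cc1c(/C=C/[S+](C)[O-])oc2ccccc2c1=O`: 1500 nM

Three measured compounds share one core and each carries a different single substituent. In a functional assay on A549 cells (Homo sapiens) for cytotoxicity, with a stated time of 48 h (on this read-out lower numbers stand for stronger inhibition and higher numbers for weaker inhibition), compound 1 gives 2200 nM and compound 3 gives 1500 nM. Compound 2 gives no number in this assay but only a limit, > 10000 nM; this is the limit of > 10000 nM in this assay, at which 1 of the 3 values shown sits. Compound 4 `C[S+]([O-])/C=C/c1cc(=O)c2cc(Cl)ccc2o1` differs from compound 2 by one change: chloro in place of cyano on an aromatic carbon. No measured step between two compounds differing in a single place is available, so the expectation rests on the compounds shown. Compound 4 is expected to come in somewhat stronger than compound 2, the estimated step being an at least 1.6-fold lower number from compound 2 to compound 4 (0.22 log units; that floor lies within the scatter), though a limit remains possible. For compound 4 the estimate in this assay is 6000 nM, with a range from 2000 nM to 20000 nM.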

Compound 4, half-maximal inhibitory concentration: 1700 nM
For compound 4 the middle estimate is 3.5-fold (0.55 log units) above the measured one, and the stated range ends above it.
By their numbers in this assay, from the lowest: compounds 3, 4 and 1 (each within the scatter of the next). At a limit, above all of these: compound 2.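

In this assay, among the compounds shown here, chloro in place of cyano on this aromatic carbon gives an at least 5.8-fold lower number from compound 2 to compound 4 (0.76 log units; beyond the scatter), the first step between two compounds that differ in one place. It shows that the group at this position can matter for the read-out. The true size of the step stays unknown, because compound 2 has only a limit and no number: the limit of > 10000 nM in this assay, at which 1 of the 4 values shown sits.

Going by these compounds, only cyano and chloro appear at this place, so how an amine or a carboxylic acid there would read remains open. On these data alone, whether chloro would give a similar step on another aromatic carbon of the shared core also remains open.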